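Trimethoxyphenyl aminotriazines: dropping the ester substituent

A few compounds are considered here, and "the series" means these few. Any claim that something is new, unique, unknown or untested is made for them only; others in the source may bear on it.

Measured so far:
compound 1 `COc1cc(Nc2nc(Nc3ccc4c(ccn4C)c3)nnc2Cl)cc(OC)c1OC`: 42100 nM in a functional assay on ECa-109 cells for inhibition, with ECa-109 cell line (Homo sapiens) as the target, read by MTT assay, with a stated time of 48 h; on this read-out higher numbers stand for weaker inhibition and lower numbers for stronger inhibition
compound 2 `COc1cc(Nc2nc(Nc3ccc(Br)cc3)nnc2Cl)cc(OC)c1OC`: 41600 nM
compound 3 `CCOC(=O)c1ccc(Nc2nnc(Cl)c(Nc3cc(OC)c(OC)c(OC)c3)n2)cc1`: 46600 nM

Compound 3 gives the highest of the three numbers, yet its gaps to compound 1 and to compound 2 are both within the scatter, so the three compounds are not separated in this assay. Compound 4 `COc1cc(Nc2nc(Nc3ccccc3)nnc2Cl)cc(OC)c1OC` derives from compound 3 by hydrogen in place of ethoxycarbonyl on an aromatic carbon. The step bearing most directly on this change is a 1.1-fold higher number from compound 2 to compound 3 (0.05 log units; within the scatter), which altered the group on the same aromatic carbon; a 1.0-fold lower number from compound 1 to compound 2 (0.01 log units; within the scatter) exchanged the whole aryl group. Both left the read-out within the scatter, so for compound 4 no step beyond the scatter is expected: a 1.1-fold lower number from compound 3 to compound 4 (0.02 log units; within the scatter). Compound 4 is therefore estimated at 44000 nM, with a range from 20000 nM to 95000 nM.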

Compound 4, half-maximal inhibitory concentration: 12600 nM
Beside the measured number, compound 4's estimate is 3.5-fold (0.54 log units) above it, outside the stated range (below it).
By their numbers in this assay, from the lowest: compound 4; then compounds 2, 1 and 3 (each within the scatter of the next).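

In this assay, hydrogen on the aromatic carbon para to a large group separates compound 4 from the substituted analogues, with a 3.7-fold lower number from compound 3 to compound 4 (0.57 log units; beyond the scatter) and a 3.3-fold lower number from compound 2 to compound 4 (0.52 log units; beyond the scatter), both modest. Replacing ethoxycarbonyl or bromo at this carbon with hydrogen therefore moves the read-out beyond the scatter, whereas exchanging bromo for ethoxycarbonyl did not. The aryl exchange also counts here, with a 3.3-fold lower number from compound 1 to compound 4 (0.52 log units; beyond the scatter), and no available data explain these differences.

As far as these compounds go, whether methyl, an amine or a carboxylic acid on this carbon would track with hydrogen or with bromo and ethoxycarbonyl remains open.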